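A few compounds are considered here, and "the series" means these few. Any claim that something is new, unique, unknown or untested is made for them only; others in the source may bear on it.

Two compounds from one series are described in a functional assay on MDA-MB-231 cells (Homo sapiens) for cytotoxicity, read by MTT assay, with a stated time of 72 h; a higher number here means a weaker inhibitor, a lower number a stronger inhibitor. Compound 1 `COc1ncc(-c2ccc3nccc(-c4ccc(Cn5cncn5)cc4)c3c2)cc1NS(=O)(=O)c1ccc(F)cc1F` has no result in this assay: in this assay compound 1 is recorded as "not determined" (no result reported), so no number exists for it. Among the measured compounds shown here, compound 2 `O=S(=O)(Nc1cc(-c2ccc3nccc(-c4ccc(Cn5cncn5)cc4)c3c2)cnc1Cl)c1ccc(F)cc1F` is the only member with a number: in this assay compound 2 gives 340 nM, and since nothing else has been measured, it stands alone and cannot be placed above or below any other compound. Compound 3 `O=S(=O)(Nc1cc(-c2ccc3nccc(-c4ccc(Cn5cncn5)cc4)c3c2)cnc1Cl)c1ccc(F)cc1` has not yet been measured. It differs from compound 2 in a single place: hydrogen in place of fluoro on an aromatic carbon. For the measured compounds named here, no step between two measured compounds is available, so there is no precedent here for the effect of hydrogen in place of fluoro on an aromatic carbon. The change removes one fluorine atom and nothing else, and the expected step from compound 2 to compound 3 is a 1.2-fold higher number from compound 2 to compound 3 (0.09 log units; within the scatter), which is expected to stay within the usual scatter of this assay, with no clear direction. Compound 3 is therefore estimated at 420 nM in this assay, with a range from 150 nM to 1200 nM.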

Compound 3, half-maximal inhibitory concentration: 228 nM
The estimate for compound 3 lay 1.8-fold (0.27 log units) above the measured number, and the stated range covers the measured number.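

In this assay, hydrogen in place of fluoro on an aromatic carbon, which turns the 2,4-difluorophenyl of the sulfonyl group into 4-fluorophenyl, gives a 1.5-fold lower number from compound 2 to compound 3 (0.17 log units; within the scatter). Among the compounds shown here, this is the only step that can be read, and it shows that this fluoro group, ortho to a large group, can give way to hydrogen with the read-out staying within the scatter, so compound 2 and compound 3 cannot be told apart in this cell assay. Nothing measured alongside these compounds speaks to why the two read alike.

From the compounds shown here alone, what a methyl group or an amine would do on the same aromatic carbon stays open, as does the effect of replacing the remaining fluoro group, which would show whether the sulfonyl aryl ring tolerates change at that place as well. Going by these compounds, it is also open whether a change elsewhere would matter more, such as at the chloro group of compound 2, since the step from there to the methoxy group of compound 1 cannot be read.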